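The compounds below may be only part of what the source reports. "The series", "measured", "known", "first", "only" and "open" are said of these compounds alone.

Three compounds have so far been measured in an assay (Rattus norvegicus) for inhibition of Fatty-acid amide hydrolase 1 (Homo sapiens); on this read-out higher numbers stand for weaker inhibition and lower numbers for stronger inhibition:

Compound 1 `Nc1cccc(-c2cnc(C(=O)CCCCCCc3ccccc3)o2)c1`: 19 nM
Compound 2 `O=C(CCCCCCc1ccccc1)c1ncc(-c2ccc(O)cc2)o1`: 140 nM
Compound 3 `NS(=O)(=O)c1ccc(-c2cnc(C(=O)CCCCCCc3ccccc3)o2)cc1`: 10 nM

Compound 3 sits at the low end of these three numbers. Its gap to compound 1 is within the scatter, so the two cannot be told apart, whereas compound 2 is clearly set off from it: a 14-fold lower number from compound 2 to compound 3 (1.15 log units; beyond the scatter). The other measured step, a 7.4-fold higher number from compound 1 to compound 2 (0.87 log units; beyond the scatter), changes both the group and its place on the ring.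

Compound 4 `N#Cc1ccc(-c2cnc(C(=O)CCCCCCc3ccccc3)o2)cc1` carries a cyano in place of sulfamoyl on an aromatic carbon, para to a large group: cyano in place of sulfamoyl on an aromatic carbon. Going by the values given here, only the step from compound 2 to compound 3 touches this same position, and it was large. The new group neither matches the sulfamoyl of compound 3 nor the hydroxy of compound 2, so a number between the two is expected, closer to compound 3. The expected step is a 3.0-fold higher number from compound 3 to compound 4 (0.48 log units; beyond the scatter). For compound 4 the estimate in this assay is 30 nM, with a range from 8 nM to 110 nM.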

Compound 4, inhibition constant: 40 nM
For compound 4 the middle estimate is 1.3-fold (0.12 log units) below the measured one; low and high end bracket the measured number.
By their numbers in this assay, from the lowest: compounds 3 and 1 (each within the scatter of the next); then compound 4; then compound 2.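

On the ring position para to a large group, replacing sulfamoyl with cyano gives a 4.0-fold higher number from compound 3 to compound 4 (0.60 log units; beyond the scatter) in this assay, while replacing hydroxy with cyano gives a 3.5-fold lower number from compound 2 to compound 4 (0.54 log units; beyond the scatter), so these three groups now form a graded series at one place on the ring. Cyano has no hydrogen-bond donor, yet it still gives a clearly lower number than hydroxy, so a donor at this place is not needed to improve on the hydroxy compound. The comparison with the amino compound, a 2.1-fold higher number from compound 1 to compound 4 (0.32 log units; beyond the scatter), changes both the group and its place on the ring, and no available evidence explains any of these differences.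

Going by these compounds, it remains open how a carboxylic acid or a carboxamide at this same place would compare with sulfamoyl and cyano. A plain phenyl ring with no added group would show whether cyano and sulfamoyl lower the number at all.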